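The compounds below may be only part of what the source reports. "The series", "measured", "known", "first", "only" and "open" are said of these compounds alone.

Of the compounds shown here, three sharing one core have been measured in a functional assay on HEK293 cells for agonist activity at Neuronal acetylcholine receptor; alpha3/beta4 (Homo sapiens), read by FLIPR; a higher number here means that more compound is needed for the effect, a lower number that less compound is needed. Compound 1 `c1cncc(N2CC[C@@H]3CN[C@@H]3C2)c1` gives 260 nM. Compound 2 `Clc1ccc(N2CC[C@H]3CN[C@H]3C2)cn1` gives 29 nM, and compound 3 `Clc1ccc(N2CC[C@@H]3CN[C@@H]3C2)cn1` gives 25 nM, the lowest of the three numbers, closest to compound 2 and farthest from compound 1. The step of a 10-fold lower number from compound 1 to compound 3 (1.02 log units; beyond the scatter) is chloro in place of hydrogen on an aromatic carbon. The step of a 1.2-fold lower number from compound 2 to compound 3 (0.06 log units; within the scatter) rests on (the fact that compounds 2 and 3 differ only in the configuration as drawn), and the two numbers sit within the scatter of each other.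

Compound 4 `COc1ccc(N2CC[C@@H]3CN[C@@H]3C2)cn1` has not been measured. Its difference from compound 3 is methoxy in place of chloro on an aromatic carbon of a six-membered aromatic ring with one nitrogen, next to the ring nitrogen. Going by the values given here, no measured step exchanges chloro for methoxy. Among the compounds with values here, the only step at this carbon is the large gain on going from hydrogen to chloro, and methoxy is neither of these groups. Compound 4 is therefore expected to show a modest step upward a 2.4-fold higher number from compound 3 to compound 4 (0.38 log units; beyond the scatter). Compound 4 is estimated at 60 nM, within a range from 20 nM to 200 nM.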

Compound 4, half-maximal effective concentration: 2400 nM
Compound 4: the middle estimate sits 40-fold (1.60 log units) below what was measured; the measured number lies above the stated range.
By their numbers in this assay, from the lowest: compounds 3 and 2 (each within the scatter of the next); then compound 1; then compound 4.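

Exchanging chloro for methoxy on this aromatic carbon, next to the ring nitrogen, gives a 96-fold higher number from compound 3 to compound 4 (1.98 log units; beyond the scatter) in this assay, so the gain seen with chloro does not carry over to every group placed here. Methoxy also ends on the far side of hydrogen, with a 9.2-fold higher number from compound 1 to compound 4 (0.97 log units; beyond the scatter), which means that a group at this carbon can push the number in either direction: among these three, chloro gives the lowest number, then hydrogen, then methoxy. Going by these compounds alone, the only available evidence concerns mirror-image forms and does not bear on this exchange.

The compounds shown leave open where fluoro, bromo, methyl, ethoxy or an amine would fall at this carbon. They also leave open whether methoxy would give a step of similar size on the mirror-image core of compound 2.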